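Chloro for Bromo on a Fused Aromatic Carbon

A few compounds are considered here, and "the series" means these few. Any claim that something is new, unique, unknown or untested is made for them only; others in the source may bear on it.

Three compounds sharing a core were tested in an ADME assay on 184B5 cells (Homo sapiens) for cytotoxicity, read by sulforhodamine B assay, with a stated time of 48 h; on this read-out higher numbers stand for weaker inhibition of growth and lower numbers for stronger inhibition of growth. Compound 1 `Cc1ccc2nc(/N=C3\C(=O)N(CN(c4ccccc4)c4ccccc4)c4cccc(Br)c43)sc2c1` gives 70300 nM in this assay. Compound 3 `O=C1C(=O)N(CN(c2ccccc2)c2ccccc2)c2cccc(Br)c21` gives 98500 nM, and compound 2 `CCN(CC)CN1C(=O)C(=O)c2c(Br)cccc21` gives 172000 nM. Among these three, compound 1 carries the lowest number, but the value of compound 3 lies within the usual scatter of it, so the two cannot be set in order; only compound 2 stands apart, with a number beyond the scatter above that of compound 1.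

The step from compound 1 leads to compound 4 `Cc1ccc2nc(/N=C3\C(=O)N(CN(c4ccccc4)c4ccccc4)c4cccc(Cl)c43)sc2c1`, which differs in a single place: chloro in place of bromo on an aromatic carbon. Within the data shown here, no measured pair in this set shows such a swap of one halogen for another on that aromatic carbon, so nothing here tells what size of step to expect from it. In the absence of such a pair, the expectation is that the exchange of bromo for chloro moves the number little, if at all, and that any shift from compound 1 to compound 4 stays within the scatter, as the expected 1.1-fold higher number from compound 1 to compound 4 (0.03 log units; within the scatter) expresses. Compound 4 is therefore expected to give about 75000 nM in this assay, somewhere between 35000 nM and 160000 nM.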

Compound 4, concentration for 50% growth inhibition: 67800 nM
Compound 4: middle estimate off by 1.1-fold (0.04 log units), on the high side; the measured number falls inside the stated range.
By their numbers in this assay, from the lowest: compounds 4, 1, 3 and 2 (each within the scatter of the next, the first and the last beyond it).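

In this assay, chloro in place of bromo on this aromatic carbon gives a 1.0-fold lower number from compound 1 to compound 4 (0.02 log units; within the scatter), so the two compounds cannot be set in order. The earlier compounds shown here all carry bromo at this position and could say nothing about a change of halogen there; this pair shows that, with the rest of compound 1 held fixed, either of these two halogens leaves the growth inhibition of these cells within the usual scatter. Nothing in the data shown bears on why the two halogens read alike.

The compounds shown leave open how this position responds to anything other than these two halogens, such as fluoro, a methyl group, a methoxy group or an amine on the same aromatic carbon. Among these compounds, they also leave open whether the same exchange would read alike on compound 2 or compound 3, since the only pair that shows it keeps the core of compound 1 unchanged.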